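Aromatic substituent swaps and cytotoxicity in one amine series

The source may report more compounds than this note shows. Statements on the series, on what has been measured and on what is new or still open speak of the compounds shown alone.

The three measured compounds share one core and differ only in the group on the five-membered aromatic ring with 1 sulfur. Compound 1 `C=Cc1ccsc1CN[C@@H]1C[C@H]2C[C@@H]([C@H]1C)C2(C)C` carries vinyl, and in an ADME assay on MDCK cells (Canis lupus familiaris) for cytotoxicity, read by microscopy, with a stated time of 48 h (on this read-out higher numbers stand for lower toxicity in this test and lower numbers for higher toxicity in this test), compound 1 gives 50000 nM. Compound 2 `C[C@H]1[C@H](NCc2sccc2Br)C[C@H]2C[C@@H]1C2(C)C` carries bromo and gives 50000 nM. The step between them is no change at the digits printed from compound 1 to compound 2 (within the scatter). Compound 3 `C[C@H]1[C@H](NCc2sccc2C2CC2)C[C@H]2C[C@@H]1C2(C)C` carries cyclopropyl and gives 25000 nM. The steps leading to it, a 2.0-fold lower number from compound 1 to compound 3 (0.30 log units; within the scatter) and a 2.0-fold lower number from compound 2 to compound 3 (0.30 log units; within the scatter), both fall within the scatter, so compound 3 is not separated from either of the other two.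

Compound 4 `CCCc1ccsc1CN[C@@H]1C[C@H]2C[C@@H]([C@H]1C)C2(C)C` is the next member: propyl in place of cyclopropyl on an aromatic carbon. Among the measured compounds shown here, no measured step involves propyl. For the measured compounds named here, the steps that bear on this change are those that swap the group at the same place, a 2.0-fold lower number from compound 1 to compound 3 (0.30 log units; within the scatter), a 2.0-fold lower number from compound 2 to compound 3 (0.30 log units; within the scatter) and no change at the digits printed from compound 1 to compound 2 (within the scatter), and all three stay within the scatter. A fourth swap of this kind is therefore expected to bring no step beyond the scatter, that is a 1.4-fold higher number from compound 3 to compound 4 (0.15 log units; within the scatter). Compound 4 is estimated at 35000 nM, with a range from 12500 nM to 100000 nM.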

Compound 4, minimum cytotoxic concentration: 50000 nM
The estimate for compound 4 lay 1.4-fold (0.15 log units) below the measured number, and the stated range covers the measured number.
By their numbers in this assay, from the lowest: compounds 3, 1, 2 and 4 (each within the scatter of the next).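

Propyl has the same heavy-atom count as cyclopropyl but no ring, and at this place, on an aromatic carbon of a five-membered aromatic ring with 1 sulfur, this assay gives a 2.0-fold higher number from compound 3 to compound 4 (0.30 log units; within the scatter); removing the three-membered ring therefore produces no step beyond the scatter. The open chain is also not separated from the other two groups, with no change at the digits printed from compound 2 to compound 4 (within the scatter) and no change at the digits printed from compound 1 to compound 4 (within the scatter). All four groups at this place now stand within the scatter of one another, and no measurement shown gives a reason for this.

From the compounds shown here alone, it remains open whether an amine, a carboxylic acid or a chain longer than propyl at this place would bring a step beyond the scatter. Also open, going by these compounds, is whether a change elsewhere on the shared core would do so in this assay.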